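Shortening the piperazine substituent of compound 2

The compounds below may be only part of what the source reports. "The series", "measured", "known", "first", "only" and "open" are said of these compounds alone.

Two members of the series carry numbers in a functional assay on SK-BR-3 cells (Homo sapiens) for antiproliferative activity, read by MTT assay, with a stated time of 72 h; on this read-out higher numbers stand for weaker inhibition and lower numbers for stronger inhibition. Compound 1 `CCN1CCN(c2cc(C)c3cc(NC(=O)c4ccccc4F)ccc3n2)CC1` gives 38100 nM. Compound 2 `Cc1cc(N2CCN(C(C)C)CC2)nc2ccc(NC(=O)c3ccc(Cl)c(Cl)c3)cc12` gives 6680 nM, the lower of the two numbers; compound 1 stands well above it, beyond the scatter. Compound 1 and compound 2 differ from each other in more than one place, so no single step can be read between them and only the two values themselves are available.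

Compound 3 `CCN1CCN(c2cc(C)c3cc(NC(=O)c4ccc(Cl)c(Cl)c4)ccc3n2)CC1` has not been measured. It derives from compound 2 by one change: hydrogen in place of methyl on a saturated chain carbon bound to an amine nitrogen in a ring and a saturated chain carbon. Among the compounds with values here, no measured pair isolates this change, so the size of the step has to be estimated. The amide side of compound 2 is untouched and only the 4-isopropylpiperazin-1-yl group becomes 4-ethylpiperazin-1-yl; such a step is expected to be small, without a clear direction, and most likely within the usual scatter. Compound 3 is therefore estimated at 8000 nM, within 3000 nM to 25000 nM. The expected step is a 1.2-fold higher number from compound 2 to compound 3 (0.08 log units; within the scatter), taken as no change beyond the scatter.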

Compound 3, half-maximal inhibitory concentration: 2160 nM
Estimate against measurement, compound 3: 3.7-fold (0.57 log units) above; measured number below the stated range.
By their numbers in this assay, from the lowest: compound 3; then compound 2; then compound 1.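

The group on the far side of the piperazine is not a silent position: with the amide side unchanged, 4-ethylpiperazin-1-yl in place of 4-isopropylpiperazin-1-yl gives a 3.1-fold lower number from compound 2 to compound 3 (0.49 log units; beyond the scatter) in this assay, a modest step but one that can now be read. Within the data shown here, with 4-ethylpiperazin-1-yl held fixed, 3,4-dichlorophenyl in place of 2-fluorophenyl on the carbonyl carbon gives an 18-fold lower number from compound 1 to compound 3 (1.25 log units; beyond the scatter), a large step and the first reading of the amide side on its own, which leaves compound 3 with the lowest number of the three. Nothing on hand accounts for either step, and both stand as observations only.

On these data alone, whether the direction of the first step holds for a methyl group, a longer chain such as n-propyl, or a 2-hydroxyethyl chain in the same place remains open, as one step cannot define a trend. Also open, as far as these compounds go, is whether the aryl change would give a similar step with 4-isopropylpiperazin-1-yl in place, and no single step can be read between compound 1 and compound 2, which differ in more than one place.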